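The source may hold more compounds than are shown below. What is called first, only, known or untested is meant among the compounds shown, and "the series" means these compounds.

Measured in a functional assay on MCF7 cells (Homo sapiens) for cytotoxicity, read by MTT assay, with a stated time of 48 h (a higher number here means a weaker inhibitor of growth, a lower number a stronger inhibitor of growth), so far:

- Compound 1 `Clc1cc2ncn(C3CCCC3)c2cc1Cl` gives 42000 nM
- Compound 2 `CC(C)c1nc2cc(Cl)c(Cl)cc2n1C1CCCC1` gives 43000 nM

On these numbers, compound 2 cannot be told apart from compound 1. Within the data shown here, the one measured step is a 1.0-fold higher number from compound 1 to compound 2 (0.01 log units; within the scatter), with isopropyl in place of hydrogen on an aromatic carbon.

Compound 3 `C[S+]([O-])c1nc2cc(Cl)c(Cl)cc2n1C1CCCC1` is not yet measured. It differs from compound 2 in one place: a group of 3 heavy atoms (1 carbon, 1 oxygen, 1 sulfur; no ring) in place of a group of 3 heavy atoms (3 carbon; no ring), on an aromatic carbon. The change lies on an aromatic carbon of a five-membered aromatic ring with 2 nitrogen, between two ring nitrogen atoms, next to the ring atom that bears a cyclopentyl group.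

Among the measured compounds shown here, only one measured step bears on this change, and it gives a weak guide. Replacing hydrogen with isopropyl produced a 1.0-fold higher number from compound 1 to compound 2 (0.01 log units; within the scatter), so a step beyond the scatter is not expected in this assay. For the measured compounds named here, no measured compound carries the incoming group, however, so the range is kept wide and neither direction is favoured.

The expected change is a 1.1-fold lower number from compound 2 to compound 3 (0.05 log units; within the scatter). For compound 3 the estimated value is 38000 nM, with an expected range from 14000 nM to 80000 nM.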

Compound 3, concentration for 50% growth inhibition: 500 nM
Beside the measured number, compound 3's estimate is 76-fold (1.88 log units) above it; the measured number lies below the stated range.
By their numbers in this assay, from the lowest: compound 3; then compounds 1 and 2 (each within the scatter of the next).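

In this assay, the aromatic carbon between two ring nitrogen atoms proves not to be indifferent to what it carries, as the flat pair of hydrogen and isopropyl had suggested: the group of 3 heavy atoms (1 carbon, 1 oxygen, 1 sulfur; no ring) gives an 86-fold lower number from compound 2 to compound 3 (1.93 log units; beyond the scatter), and set against hydrogen it gives an 84-fold lower number from compound 1 to compound 3 (1.92 log units; beyond the scatter). The count of heavy atoms does not follow this step, since the leaving isopropyl and the entering group hold the same number, and they differ instead in which atoms they hold and in the one hydrogen-bond acceptor counted on the entering group. Nothing measured here accounts for the size of the step.

The compounds shown do not separate the contribution of the sulfur from that of the oxygen, so it stays open how a thioether, a sulfone or an amine on this carbon would stand. They also leave open whether the step would persist if a longer chain took the place of the cyclopentyl group.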